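From methylsulfonyl to chloro: working notes on the series

The source may report more compounds than this note shows. Statements on the series, on what has been measured and on what is new or still open speak of the compounds shown alone.

- compound 1 `CS(=O)(=O)Nc1ccc(-c2cc(C(=O)N[C@H]3CCCNC3)c(NC(N)=O)s2)cc1`: 2200 nM
- compound 2 `CS(=O)(=O)c1ccc(-c2cc(C(=O)N[C@H]3CCCNC3)c(NC(N)=O)s2)cc1`: 200 nM

Both values come from a functional assay on HT-29 cells (Homo sapiens); on this read-out lower numbers stand for an effect already at smaller amounts and higher numbers for an effect only at larger amounts of compound. Of the two measured compounds, compound 2 stands lowest at 200 nM. Compound 3 `NC(=O)Nc1sc(-c2ccc(Cl)cc2)cc1C(=O)N[C@H]1CCCNC1` carries chloro in place of methylsulfonyl on an aromatic carbon. Among the compounds with values here, only one measured step bears on this place: an 11-fold lower number from compound 1 to compound 2 (1.04 log units; beyond the scatter), a large step with methylsulfonyl in place of methanesulfonamido on an aromatic carbon. Within the data shown here, that step shows that the number can move strongly with the group here, but no chloro compound has been measured, so its guidance is limited. A moderate step towards a higher number is therefore expected in this assay, and a result within the scatter would not be surprising. The expected step is a 2.3-fold higher number from compound 2 to compound 3 (0.35 log units; beyond the scatter). For compound 3 the estimated value is 450 nM, with an expected range of 120 nM to 1500 nM.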

Compound 3, half-maximal effective concentration: 40 nM
Compound 3: the middle estimate sits 11-fold (1.05 log units) above what was measured, outside the stated range (below it).
By their numbers in this assay, from the lowest: compound 3; then compound 2; then compound 1.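

In this assay, this position on the six-membered aromatic ring does not depend on a sulfonyl group: chloro, which brings no hydrogen-bond acceptors, gives a 5.0-fold lower number from compound 2 to compound 3 (0.70 log units; beyond the scatter) and so exceeds the gain seen with methylsulfonyl. Within the data shown here, the comparison with the methanesulfonamido group is wider still, with a 55-fold lower number from compound 1 to compound 3 (1.74 log units; beyond the scatter) as the largest step so far, and the three groups now rank chloro, methylsulfonyl, methanesulfonamido, from the lowest number to the highest. Nothing available explains this order or says what lies behind the step to chloro.

Going by these compounds, it remains open whether the trend continues with other groups at this place, such as fluoro, bromo, trifluoromethyl or methoxy, or whether chloro is a particular case. An amine or a carboxylic acid here would test how far the number depends on the group's charge.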